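Adding bromo to compound 3: working notes

The source may hold more compounds than are shown below. What is called first, only, known or untested is meant among the compounds shown, and "the series" means these compounds.

Of the compounds shown here, three sharing one core have been measured in a functional assay on NCI-H520 cells (Homo sapiens); a lower number here means a stronger inhibitor of growth, a higher number a weaker inhibitor of growth. Compound 1 `O=S(=O)(/C=C/c1ccccc1)Cc1ccc(Nc2ncnc3ccccc23)cc1` stands at the limit of > 100000 nM in this assay, at which 1 of the 3 values shown sits, reported as > 100000 nM, a limit and not a number. Compound 2 `O=S(=O)(/C=C/c1ccc(Cl)cc1Cl)Cc1ccc(Nc2ncnc3ccccc23)cc1` gives 12000 nM, and compound 3 `O=S(=O)(/C=C/c1ccc(C(F)(F)F)cc1F)Cc1ccc(Nc2ncnc3ccccc23)cc1` gives 100000 nM. Compound 3 therefore holds the higher of the two actual numbers.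

All measured steps exchange the group on the double-bonded chain carbon. They are an at least 8.3-fold lower number from compound 1 to compound 2 (0.92 log units; beyond the scatter), a number no higher from compound 1 to compound 3 (the limit leaves the size open) and an 8.3-fold higher number from compound 2 to compound 3 (0.92 log units; beyond the scatter). The first and third are modest but beyond the scatter, while the size of the second cannot be read.

Compound 4 `O=S(=O)(/C=C/c1ccc(C(F)(F)F)cc1F)Cc1ccc(Nc2ncnc3ccc(Br)cc23)cc1` keeps the 2-fluoro-4-(trifluoromethyl)phenyl group of compound 3 and changes elsewhere: bromo in place of hydrogen on an aromatic carbon. Among the measured compounds shown here, no measured step touches that place, so these steps serve only as a rough guide to size. With compound 3 at 100000 nM, the higher of the two actual numbers, a modest fall is expected, with wide uncertainty. The expected change is a 3.3-fold lower number from compound 3 to compound 4 (0.52 log units; beyond the scatter). For compound 4 the estimated value is 30000 nM, with an expected range from 5000 nM to 100000 nM.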

Compound 4, concentration for 50% growth inhibition: 40000 nM
Estimate against measurement, compound 4: 1.3-fold (0.12 log units) below; the measured number falls inside the stated range.
By their numbers in this assay, from the lowest: compound 2; then compound 4; then compound 3.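

Bromo in place of hydrogen on an aromatic carbon, in the six-membered aromatic ring of carbon only that is part of the fused system, gives a 2.5-fold lower number from compound 3 to compound 4 (0.40 log units; beyond the scatter) in this assay. Among the compounds shown here, the earlier steps all exchanged the group on the double-bonded chain carbon, so this is the first sign that the shared core itself can shift the number: a change of one heavy atom, with no ring, no hydrogen-bond donor or acceptor and no net charge, moves it beyond the scatter, though only modestly. Nothing among the data shown accounts for this step.

As far as these compounds go, it stays open whether bromo at this place would give a step of similar size and direction alongside the 2,4-dichlorophenyl group of compound 2, since one pair cannot show whether the effect carries over between side groups. Also open, from the compounds shown here alone, is how the number would respond at this same aromatic carbon to chloro, methoxy, an amine or a carboxylic acid, and so whether the step is particular to bromo or holds for other groups there.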